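Aryl piperazine swap in a paw edema series

The source may hold more compounds than are shown below. What is called first, only, known or untested is meant among the compounds shown, and "the series" means these compounds.

Measured so far:
Compound 1 `CC(C)Cc1ccc(C(C)c2nn(CN3CCN(c4ccc(F)cc4)CC3)c(=S)o2)cc1` — in a functional assay on the whole organism (strain Wister albino) for inhibition, with Rattus norvegicus as the target, read by paw edema, with stated times of 30 min and 3 h, at a dose of 10 mg/kg by the oral route (a lower number here means less inhibition, a higher number more inhibition at the dose given (going by the name of the read-out)), compound 1 gives 75.4%.
Compound 2 `CCOc1ccccc1N1CCN(Cn2nc(C(C)c3ccc(CC(C)C)cc3)oc2=S)CC1` — in this assay compound 2 gives 44.6%.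
Compound 3 `CSc1ccc(Cc2nn(CN3CCN(c4ccc(F)cc4)CC3)c(=S)o2)cc1` — in this assay compound 3 gives 68.7%.

Compound 1 and compound 3 carry different cores; that difference is not broken down here. Compound 3 and compound 1 lie within the scatter of each other, while compound 2 sits lower than both.

For the measured compounds named here, the one counted change is 2-ethoxyphenyl in place of 4-fluorophenyl on an amine nitrogen in a ring, which made a number 30.8 percentage points lower from compound 1 to compound 2 (beyond the scatter). Compound 4 `CCOc1ccccc1N1CCN(Cn2nc(Cc3ccc(SC)cc3)oc2=S)CC1` carries the same change on the core of compound 3: 2-ethoxyphenyl in place of 4-fluorophenyl on an amine nitrogen in a ring. The place lines agree word for word, so this is the same change made once more.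

A step of similar size is expected, a number 30.7 percentage points lower from compound 3 to compound 4 (beyond the scatter), because the earlier instance gave a number 30.8 percentage points lower from compound 1 to compound 2 (beyond the scatter). Compound 4 is therefore estimated at 38%, with a range of 22% to 55%.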

Compound 4, a percentage reported as inhibition, in the whole organism at one dose (the size of the read-out at that dose, not a potency): 42.5%
Beside the measured number, compound 4's estimate is 4.5 percentage points below it; low and high end bracket the measured number.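

In this assay, 2-ethoxyphenyl in place of 4-fluorophenyl on an amine nitrogen in a ring gave a number 26.2 percentage points lower from compound 3 to compound 4 (beyond the scatter). The change therefore carries over from the core of compound 1 to the core of compound 3 with a step of similar size: the same change on two cores in this assay, a number 30.8 percentage points lower (beyond the scatter) from compound 1 to compound 2 and a number 26.2 percentage points lower (beyond the scatter) from compound 3 to compound 4, 4.6 percentage points apart, within the scatter of two such steps

This agreement rests on these two cores and one oral dose only; it does not show that the step holds on other cores, and it does not say which feature of the swapped groups accounts for it. The compounds shown leave open whether an unsubstituted phenyl, a 2-fluorophenyl or a 4-ethoxyphenyl on that nitrogen would give a step of this size. They also leave open how the step would behave at other doses.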